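This account rests on a few compounds, and the source may have more. Where it says the series, first, only, none or still open, it means among the compounds named here.

Among the measured compounds shown here, in an ADME assay on MDBK cells (Bos taurus) for cytotoxicity, read by MTT assay, with a stated time of 96 h (a higher number here means that more compound is tolerated, a lower number that less compound is tolerated), only two compounds have been measured so far. Compound 1 (`Cc1ccc(/N=N/c2ccc(NCCCN(C)C)cc2)cc1`) gives > 100000 nM, which is a limit of the assay and not a number. Compound 2 (`O=[N+]([O-])c1ccc(/N=N/N2CCCC2)cc1`) gives > 100000 nM, which is likewise a limit. The whole picture is thus (the limit of > 100000 nM in this assay, at which 2 of the 2 values shown sit), and no actual number fixes where compound 2 stands.

Compound 3 (`Clc1ccc(/N=N/N2CCCC2)cc1`) has not yet been measured in this assay. It keeps the shared core of compound 2 but carries chloro in place of nitro on an aromatic carbon, para to a group of 7 heavy atoms: chloro in place of nitro on an aromatic carbon. For the measured compounds named here, no measured pair shows what this exchange does, so the expectation rests only on compound 2 with its limit of > 100000 nM. A large change is not expected, though a modest move toward less compound being tolerated is possible, and the assay may again report only a limit. The estimated step of an at least 1.4-fold lower number from compound 2 to compound 3 (0.15 log units; that floor lies within the scatter) is expected to stay small. Compound 3 is expected to give 70000 nM, with an estimated range from 25000 nM to 100000 nM.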

Compound 3, half-maximal cytotoxic concentration: > 100000 nM
Compound 3 ended at the assay's limit; the forecaster's own chance of this, stated with the estimate: 55%; at least 1.4-fold (0.15 log units) between middle value and limit.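

The exchange of chloro for nitro from compound 2 to compound 3 yields no step that can be read, since both compounds end at the limit of this assay: the limit of > 100000 nM in this assay, at which 3 of the 3 values shown sit.

The compounds shown leave open how much of any of them is actually tolerated, and whether any change to these structures would give a readable number in this assay.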